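A methyl on the bridging carbon: what compound 4 may give

A few compounds are considered here, and "the series" means these few. Any claim that something is new, unique, unknown or untested is made for them only; others in the source may bear on it.

Of the compounds shown here, three of one series have been measured in a functional assay on the whole organism (Abdomen) with Mus musculus as the target; a lower number here means that less compound is needed, a higher number that more compound is needed for the effect. Compound 1 `CC(C)c1nc(Cc2c[nH]cn2)c(C(C)C)s1` gives 23.8 mg/kg in this assay. Compound 2 `CCc1sc(C(C)C)nc1Cc1c[nH]cn1` gives 7.5 mg/kg in this assay. Compound 3 `CCc1nc(CC)c(Cc2c[nH]cn2)s1` reaches only the limit of this assay, > 30 mg/kg, and no number is known for it; that limit is the limit of > 30 mg/kg in this assay, at which 1 of the 3 values shown sits.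

Compound 1 differs from compound 2 by methyl in place of hydrogen on a saturated chain carbon bound to an aromatic carbon and a saturated chain carbon, and this change brought a 3.2-fold higher number from compound 2 to compound 1 (0.50 log units; beyond the scatter). The difference between the cores of compound 2 and compound 3 is not broken down here.

Compound 4 `CCc1nc(CC)c(C(C)c2c[nH]cn2)s1` has not been measured in this assay. It differs from compound 3 by methyl in place of hydrogen on a saturated chain carbon bound to two aromatic carbons. Among the compounds with values here, this is the same kind of change as the one from compound 2 to compound 1, but not the same: there the entering methyl sits on a saturated chain carbon bound to an aromatic carbon and a saturated chain carbon, here on a saturated chain carbon bound to two aromatic carbons. Within the data shown here, with compound 3 already at a limit, there is no number from which a step could be measured, and the single earlier instance points toward a higher number rather than a lower one.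

Compound 4 is therefore expected to give about 60 mg/kg in this assay. For compound 4 the expected range runs from 15 mg/kg to 250 mg/kg. The step this expectation means is a step that the limit leaves unreadable from compound 3 to compound 4, and it rests only on the step from compound 2 to compound 1 and on the limit of compound 3, so a further limit rather than a number is the more likely outcome.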

Compound 4, dose for half-maximal effect: > 30 mg/kg
Compound 4 was reported as a limit; the forecaster's own chance of this, stated with the estimate: 70%; the middle value is on the limit's open side.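

In this assay, compound 4 reaches only a limit, > 30 mg/kg. Compound 3 is also only a limit, > 30 mg/kg, so no step can be read between compound 3 and compound 4: the limit of > 30 mg/kg in this assay, at which 2 of the 4 values shown sit.

The compounds shown leave open what number either compound would give, and whether methyl in place of hydrogen on a saturated chain carbon bound to two aromatic carbons changes the number at all.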